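This account rests on a few compounds, and the source may have more. Where it says the series, first, only, none or still open, it means among the compounds named here.

Measured so far:
compound 1 `C[C@H]1[C@H](NCc2cc(C3CC3)cs2)C[C@H]2C[C@@H]1C2(C)C`: 25000 nM
compound 2 `C[C@H]1[C@H](NCc2cncnc2)C[C@H]2C[C@@H]1C2(C)C`: > 100000 nM, a limit of the assay rather than a number

Both compounds were tested in an ADME assay on MDCK cells (Canis lupus familiaris) for cytotoxicity, read by microscopy, with a stated time of 48 h; on this read-out higher numbers stand for lower toxicity in this test and lower numbers for higher toxicity in this test. Compound 1 gives a real number, 25000 nM, in this assay. For compound 2 the result is only a limit, > 100000 nM, and it is one of the values that sit at the limit of > 100000 nM in this assay, at which 1 of the 2 values shown sits. So compound 2 stands at the edge of what the test can report, and no step between the two measured compounds can be counted.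

Compound 3 `C[C@H]1[C@H](NCc2nccs2)C[C@H]2C[C@@H]1C2(C)C` has not yet been measured in this assay. It differs from compound 2 in one place: 1,3-thiazol-2-yl in place of pyrimidin-5-yl on a saturated chain carbon bound to an amine nitrogen. The thiazole is a smaller ring than the pyrimidine it replaces, and it carries a sulfur atom, a feature it shares with the thiophene of compound 1, whose value in this assay is a number rather than a limit. On that basis the step of an at least 1.6-fold lower number from compound 2 to compound 3 (0.22 log units; that floor lies within the scatter) is expected to be small, pointing toward somewhat higher toxicity, and may well stay within the scatter. Compound 3 is therefore estimated at 60000 nM, with a likely range from 20000 nM to 200000 nM, and a fair chance that the assay again reports only a limit.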

Compound 3, minimum cytotoxic concentration: > 100000 nM
Compound 3 gave a limit, no number; the forecaster's own chance of this, stated with the estimate: 45%; middle value at least 1.6-fold (0.22 log units) away from the limit.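

Compound 3, like compound 2, gave only a limit of the assay rather than a number, so no step from one to the other can be read: the limit of > 100000 nM in this assay, at which 2 of the 3 values shown sit.

The compounds shown leave open whether 1,3-thiazol-2-yl in place of pyrimidin-5-yl changes the result in this assay at all, and how far either compound lies beyond that limit.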